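Cyclopropyl for allyl on the amide nitrogen in toxicity

A few compounds are considered here, and "the series" means these few. Any claim that something is new, unique, unknown or untested is made for them only; others in the source may bear on it.

The study compares three measured compounds and one not yet measured. Compound 1 `COc1ccc(/C(C)=C(\C)C(=O)NC2CC2)cc1` in a toxicity assay on the whole organism (strain Icem-CET (SPF Caw)) for cytotoxicity, with Mus musculus as the target (on this read-out lower numbers stand for an effect already at smaller amounts and higher numbers for an effect only at larger amounts of compound), gives 300 mg/kg. Going by the values given here, compound 2 `C/C(C(=O)NC1CC1)=C(/C)c1ccc(F)cc1` in this assay gives 200 mg/kg, and the one step between measured compounds, a 1.5-fold lower number from compound 1 to compound 2 (0.18 log units; within the scatter), comes from fluoro in place of methoxy on an aromatic carbon. Compound 3 `C=CCNC(=O)/C(C)=C(\C)c1ccc(C)cc1` in this assay gives 170 mg/kg, which is the lowest of the three numbers, though its gaps to compound 2 and to compound 1 both lie within the scatter, so no order among the three can be claimed.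

Compound 4 `C/C(C(=O)NC1CC1)=C(/C)c1ccc(C)cc1` differs from compound 3 in one place: cyclopropyl in place of allyl on an amide-type nitrogen. Among the compounds with values here, no measured step covers this change directly. What the data offer is that compound 1 and compound 2, both carrying cyclopropyl on the amide nitrogen, sit within the scatter of compound 3 in this assay. Compound 4 is therefore expected to show no step beyond the scatter, a 1.2-fold higher number from compound 3 to compound 4 (0.07 log units; within the scatter). Compound 4 is estimated at 200 mg/kg, with a range from 120 mg/kg to 350 mg/kg in this assay.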

Compound 4, dose for half-maximal effect: 300 mg/kg
Estimate against measurement, compound 4: 1.5-fold (0.18 log units) below; the range from low to high includes it.
By their numbers in this assay, from the lowest: compounds 3, 2, 1 and 4 (each within the scatter of the next).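

In this assay, the change from allyl to cyclopropyl on an amide-type nitrogen now has a direct reading, a 1.8-fold higher number from compound 3 to compound 4 (0.25 log units; within the scatter), so this position shows no effect that can be told from the scatter. With cyclopropyl kept on the nitrogen, the aromatic carbon likewise gives no readable effect: methyl in place of fluoro gives a 1.5-fold higher number from compound 2 to compound 4 (0.18 log units; within the scatter), and methyl in place of methoxy gives no change at the digits printed from compound 1 to compound 4 (within the scatter). No evidence on the origin of these small steps is available.

Going by these compounds, whether a longer chain or a chain ending in an amine on the amide nitrogen would give a step beyond the scatter stays open. So does the outcome of a carboxylic acid or a hydroxyl on the aromatic carbon.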